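The compounds below may be only part of what the source reports. "The series", "measured", "known", "first", "only" and "open" are said of these compounds alone.

Compound 1 `CCOC(=O)c1cnn(-c2nc(-c3ccccc3Cl)c(C#N)c(=O)n2C)c1N`: 93 ug/mL
Compound 2 `CCOC(=O)c1cnn(-c2nc(-c3cccs3)c(C#N)c(=O)n2C)c1N`: 98 ug/mL
Compound 3 `CCOC(=O)c1cnn(-c2nc(-c3ccccc3O)c(C#N)c(=O)n2C)c1N`: 64 ug/mL

In a functional assay, with a stated time of 150 min (on this read-out lower numbers stand for stronger inhibition and higher numbers for weaker inhibition), compound 3 gives the lowest of the three numbers, yet the gaps that separate it from the other two are within the scatter, as a 1.5-fold lower number from compound 1 to compound 3 (0.16 log units; within the scatter) and a 1.5-fold lower number from compound 2 to compound 3 (0.19 log units; within the scatter) show. Compound 4 `CCOC(=O)c1cnn(-c2nc(-c3cccc(O)c3O)c(C#N)c(=O)n2C)c1N` is the next compound to be measured; it differs from compound 3 by hydroxy in place of hydrogen on an aromatic carbon. For the measured compounds named here, no measured step adds a hydroxy to a ring that already carries one. The step that comes closest is a 1.5-fold lower number from compound 1 to compound 3 (0.16 log units; within the scatter), where a hydroxy replaced a chloro, and the other change on this ring, a 1.1-fold higher number from compound 1 to compound 2 (0.02 log units; within the scatter), also stayed within the scatter. On this evidence the author expects no step beyond the scatter in this assay, and the direction cannot be told from the measured compounds. For compound 4 he therefore estimates 60 ug/mL, with a range from 30 ug/mL to 120 ug/mL. The expected step is a 1.1-fold lower number from compound 3 to compound 4 (0.03 log units; within the scatter).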

Compound 4, half-maximal inhibitory concentration: 58 ug/mL
Compound 4: middle estimate off by 1.0-fold (0.01 log units), on the high side; measured number inside the range.
By their numbers in this assay, from the lowest: compounds 4, 3, 1 and 2 (each within the scatter of the next).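

In this assay, the change from 2-hydroxyphenyl to 2,3-dihydroxyphenyl places a hydroxy ortho to a hydroxy group and gives a step within the scatter (a 1.1-fold lower number from compound 3 to compound 4 (0.04 log units; within the scatter)), so this first change on a ring already carrying a hydroxy does not separate the two compounds. The 2,3-dihydroxyphenyl group also remains within the scatter of the thiophen-2-yl (a 1.7-fold lower number from compound 2 to compound 4 (0.23 log units; within the scatter)) and 2-chlorophenyl (a 1.6-fold lower number from compound 1 to compound 4 (0.21 log units; within the scatter)) groups, which extends the flat picture to all four compounds. Nothing measured here bears on a cause for this result.

Going by these compounds, whether a methoxy or an amine in place of the new hydroxy would give a step beyond the scatter remains open. On these data alone, all four compounds also keep the ethyl ester, so the effect of a carboxylic acid or an amide there is unknown.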